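The compounds below may be only part of what the source reports. "The series", "measured", "known", "first", "only" and "open" are said of these compounds alone.

Compound 2 `COc1ccc(-c2ccc(CO[C@H]3C[C@@H](N=C=S)C3)c(F)c2)cc1F` gives 20.6 nM in an assay on isolated protein for inhibition of N-acylethanolamine-hydrolyzing acid amidase (Homo sapiens), read by fluorescence, with a stated time of 90 min (on this read-out higher numbers stand for weaker inhibition and lower numbers for stronger inhibition), and stands second highest of the three numbers, nearest compound 1 `COc1ccc(-c2ccc(C(C)O[C@H]3C[C@@H](N=C=S)C3)c(F)c2)cc1F` at 14.6 nM and furthest from compound 3 `Fc1cc(-c2ccc(OC(F)(F)F)c(F)c2)ccc1CO[C@H]1C[C@@H](N=C=S)C1` at 97.1 nM. Compound 4 `COc1ccc(-c2ccc(CN3CC(N=C=S)C3)c(F)c2)cc1F` differs from compound 2 by a group of 7 heavy atoms (4 carbon, 2 nitrogen, 1 sulfur; one four-membered non-aromatic ring with 1 hetero atom) in place of a group of 8 heavy atoms (5 carbon, 1 nitrogen, 1 oxygen, 1 sulfur; one four-membered non-aromatic ring of carbon only), on a saturated chain carbon bound to an aromatic carbon. Of the measured steps, only a 1.4-fold higher number from compound 1 to compound 2 (0.15 log units; within the scatter) touches the same saturated chain carbon, and it stayed within the scatter; the step of a 4.7-fold higher number from compound 2 to compound 3 (0.67 log units; beyond the scatter) sits elsewhere and was modest. Neither step changes the four-membered ring or the oxygen that leaves here, so no measured change bears directly on this replacement. A weakening beyond the scatter is nonetheless expected, a 4.9-fold higher number from compound 2 to compound 4 (0.69 log units; beyond the scatter). Compound 4 is therefore estimated at 100 nM, with a range from 25 nM to 500 nM.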

Compound 4, half-maximal inhibitory concentration: 176 nM
The estimate for compound 4 lay 1.8-fold (0.25 log units) below the measured number; the measured number falls inside the stated range.
By their numbers in this assay, from the lowest: compounds 1 and 2 (each within the scatter of the next); then compounds 3 and 4 (each within the scatter of the next).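

In this assay, the replacement on the saturated chain carbon bound to an aromatic carbon gave an 8.5-fold higher number from compound 2 to compound 4 (0.93 log units; beyond the scatter), whereas a 1.4-fold higher number from compound 1 to compound 2 (0.15 log units; within the scatter) had stayed within the scatter. This position therefore does respond to the group it carries, with weaker inhibition when the oxygen leaves and the four-membered ring gains 1 hetero atom. No supporting measurement explains this step.

From the compounds shown here alone, the oxygen and the ring change together in this one step, so their separate contributions remain open. Going by these compounds, how a pyrrolidine ring or an amide linker would fare at this place also remains open.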